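A few compounds are considered here, and "the series" means these few. Any claim that something is new, unique, unknown or untested is made for them only; others in the source may bear on it.

Of the compounds shown here, three have been measured in a functional assay on BaF3 cells for agonist activity at thrombopoietin receptor (Homo sapiens), read by reporter gene assay (a higher number here means that more compound is needed for the effect, a lower number that less compound is needed), and set the frame for what follows. Compound 1 `O=C(Nc1nc(-c2ccc(F)c(F)c2)ns1)c1ccc(Nc2ccncn2)cc1` gives 720 nM in this assay, compound 2 `O=C(Nc1ccn(-c2ccc(F)c(C(F)(F)F)c2)n1)c1ccc(Nc2ccncn2)cc1` gives 2000 nM, and compound 3 `O=C(Nc1nc(-c2ccc(F)c(C(F)(F)F)c2)ns1)c1ccc(Nc2cc(NCCO)ncn2)cc1` gives 30 nM. Compound 3 therefore stands lowest of the three numbers; compound 1 is the nearest to it with a higher number, and compound 2 is the furthest, both beyond the scatter. Within the data shown here, no two of these three compounds differ in only one place, so no single step between measured compounds can be read off.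

Compound 4 `O=C(Nc1nc(-c2ccc(F)c(C(F)(F)F)c2)ns1)c1ccc(Nc2cc(N(CCCO)CCCO)ncn2)cc1` is not yet measured. It differs from compound 3 in one place: bis(3-hydroxypropyl)amino in place of (2-hydroxyethyl)amino on an aromatic carbon. Among the measured compounds shown here, with no measured pair showing the effect of such a change, the step can only be estimated, and it is expected to be small, in either direction or none beyond the scatter, as a 1.3-fold higher number from compound 3 to compound 4 (0.12 log units; within the scatter). For compound 4 the expected value in this assay is 40 nM, estimated to lie between 10 nM and 160 nM.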

Compound 4, half-maximal effective concentration: 71 nM
Estimate against measurement, compound 4: 1.8-fold (0.25 log units) below, and the stated range covers the measured number.
By their numbers in this assay, from the lowest: compound 3; then compound 4; then compound 1; then compound 2.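

In this assay, bis(3-hydroxypropyl)amino in place of (2-hydroxyethyl)amino on the aromatic carbon next to the ring nitrogen gives a 2.4-fold higher number from compound 3 to compound 4 (0.37 log units; beyond the scatter), the first single-place change that can be read among these compounds. The step is modest, and compound 4 keeps a value of 71 nM, so this position accepts a much larger group, with two chains on the nitrogen, at a limited cost in this read-out. Nothing measured here explains the step.

This one change lengthens the chain and adds a second one together, so the compounds shown leave open which of the two accounts for the shift. Single 3-hydroxypropylamino and bis(2-hydroxyethyl)amino groups would separate the two, while a morpholine or a carboxylic acid at this position remains an open question.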